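A few compounds are considered here, and "the series" means these few. Any claim that something is new, unique, unknown or untested is made for them only; others in the source may bear on it.

Of the compounds shown here, three sharing one core have so far been measured in an ADME assay on L02 cells (Homo sapiens) for cytotoxicity, read by MTT assay, with a stated time of 24 h; on this read-out higher numbers stand for lower toxicity in this test and lower numbers for higher toxicity in this test. Compound 1 `CC1(C)[C@H]2CC[C@]1(C)N(Cc1cn(-c3cccc(Cl)c3)nn1)C(=O)C2` gives 8510 nM. Compound 2 `CC1(C)[C@H]2CC[C@]1(C)N(Cc1cn(-c3ccccc3)nn1)C(=O)C2` gives 6230 nM, and compound 3 `CC1(C)[C@H]2CC[C@]1(C)N(Cc1cn(-c3ccccc3C#N)nn1)C(=O)C2` gives 46100 nM. Of these three numbers, that of compound 1 is the second highest; its nearest neighbour is compound 2, with a 1.4-fold lower number from compound 1 to compound 2 (0.14 log units; within the scatter), and its furthest is compound 3, with a 5.4-fold higher number from compound 1 to compound 3 (0.73 log units; beyond the scatter).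

Compound 4 `CC1(C)[C@H]2CC[C@]1(C)N(Cc1cn(-c3ccc(C#N)cc3)nn1)C(=O)C2` is not yet measured. It differs from compound 1 in one place: 4-cyanophenyl in place of 3-chlorophenyl on an aromatic nitrogen.

For the measured compounds named here, two measured steps bear on this. Both a 5.4-fold higher number from compound 1 to compound 3 (0.73 log units; beyond the scatter) and a 7.4-fold higher number from compound 2 to compound 3 (0.87 log units; beyond the scatter) brought a cyanophenyl group onto the same ring nitrogen and both raised the number by a modest amount beyond the scatter. Going by the values given here, in compound 4 the nitrile sits at a different position of the phenyl ring, so the steps are not an exact match, but they are the only guide. Compound 4 is therefore expected to show a modest step upward, estimated as a 2.9-fold higher number from compound 1 to compound 4 (0.47 log units; beyond the scatter). Compound 4 is expected to give an estimated value of 25000 nM, with an expected range from 8000 nM to 75000 nM.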

Compound 4, half-maximal cytotoxic concentration: 15700 nM
Compound 4: the middle estimate sits 1.6-fold (0.20 log units) above what was measured, and the stated range covers the measured number.
By their numbers in this assay, from the lowest: compounds 2, 1 and 4 (each within the scatter of the next, the first and the last beyond it); then compound 3.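

In this assay, the place of the nitrile on the phenyl ring matters: changing the 2-cyanophenyl group to the 4-cyanophenyl group gives a 2.9-fold lower number from compound 3 to compound 4 (0.47 log units; beyond the scatter), so the large rise seen earlier does not hold for every cyanophenyl group. For the compounds shown here, the 4-cyanophenyl group still raises the number relative to unsubstituted phenyl, with a 2.5-fold higher number from compound 2 to compound 4 (0.40 log units; beyond the scatter), but this step is smaller than the one to the 2-cyanophenyl group. Against the 3-chlorophenyl group, it gives a 1.8-fold higher number from compound 1 to compound 4 (0.27 log units; within the scatter), so these two groups cannot be told apart in this test.

Nothing available here explains why the place of the nitrile changes the result. Also open, on these data alone, is how a methoxy group, an amine or a carboxylic acid on the same phenyl ring would compare with the nitrile.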